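A few compounds are considered here, and "the series" means these few. Any claim that something is new, unique, unknown or untested is made for them only; others in the source may bear on it.

Working notes on the series, all sharing one core. Among the measured compounds shown here, in an ADME assay on cells (Epithelial cell, Homo sapiens) for antiproliferative activity, read by MTT assay, with a stated time of 48 h (a lower number here means a stronger inhibitor, a higher number a weaker inhibitor), compound 1 `COC(=O)/C(=C/c1ccccc1)CN1C(=O)[C@@H](OC)[C@H]1c1ccc(F)cc1` gives 27900 nM, the only number so far. Compound 2 `COC(=O)/C(=C/c1ccccc1)CN1C(=O)[C@@H](OC)[C@H]1c1cccc(Cl)c1` is recorded as "not toxic" (no number reported). Compound 3 `COC(=O)/C(=C/c1ccccc1)CN1C(=O)[C@@H](OC)[C@H]1c1ccccc1`, the unsubstituted phenyl member, is recorded as "not toxic" (no number reported), so it has no single number and cannot be placed on a scale against compound 1.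

Still unmeasured is compound 4 `COC(=O)/C(=C/c1ccccc1)CN1C(=O)[C@@H](OC)[C@H]1c1cccc(C(F)(F)F)c1`. The structural change trifluoromethyl in place of hydrogen on an aromatic carbon is trifluoromethyl in place of hydrogen on an aromatic carbon, meta to a large group, or phenyl to 3-(trifluoromethyl)phenyl.

For the measured compounds named here, no measured step shows what a single substitution does in this assay, so the size of this one cannot be read from the data. The expectation is a modest shift at most, towards measurable inhibition, or no change from the no-number outcome of compound 3. Going by the values given here, the only anchor is compound 1 at 27900 nM, and a result without a number remains quite possible. For compound 4 the expected value is 30000 nM, with an estimated range of 10000 nM to 90000 nM.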

Compound 4, half-maximal inhibitory concentration: 71800 nM
Compound 4: middle estimate off by 2.4-fold (0.38 log units), on the low side, within the range that was stated.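

Where compound 3 is recorded as "not toxic" with no number, in this assay compound 4, with trifluoromethyl in place of hydrogen on an aromatic carbon, gives 71800 nM; the step between these two cannot be read. A substituted phenyl at this position can thus give a number even where the unsubstituted member has none, and the two numbers in the series differ, with a 2.6-fold higher number from compound 1 to compound 4 (0.41 log units; beyond the scatter), as 3-(trifluoromethyl)phenyl stands in place of 4-fluorophenyl. No measurement on hand accounts for this result.

Going by these compounds, whether the gap between compound 1 and compound 4 follows the group itself or its place on the ring remains open. Also open, on these data alone, is what an amine or a carboxylic acid in place of the same hydrogen would give in this assay.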